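A few compounds are considered here, and "the series" means these few. Any claim that something is new, unique, unknown or untested is made for them only; others in the source may bear on it.

Compound 1 `O=c1cc(-c2ccc(OCc3ccccc3)cc2)oc2cc(OCCCCCCCCN3CCCC3)ccc12` gives 10.4% in an ADME assay on HepG2 cells (Homo sapiens) for cytotoxicity, read by MTT assay, with a stated time of 48 h, tested at 1 uM; on this read-out lower numbers stand for a weaker effect and higher numbers for a stronger effect at the one concentration tested. Compound 2 `O=c1cc(-c2ccccc2)oc2cc(OCCCCCCCCN3CCCC3)ccc12` gives 11.3%. Compound 3 `O=c1cc(-c2ccccc2OCc2ccccc2)oc2cc(OCCCCCCCCN3CCCC3)ccc12` gives 19.7%.

Among these three numbers compound 2 holds the second highest. The step of a number 0.9 percentage points higher from compound 1 to compound 2 (within the scatter) and the step of a number 8.4 percentage points higher from compound 2 to compound 3 (within the scatter) both stay within the scatter, so the three measured compounds cannot be ordered on this read-out.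

Compound 4 `COc1cc(-c2cc(=O)c3ccc(OCCCCCCCCN4CCCC4)cc3o2)cc(OC)c1OC` differs from compound 2 by 3,4,5-trimethoxyphenyl in place of phenyl on an aromatic carbon. The two measured steps are the ones that bear on this change, since both alter the substitution of the same phenyl, and neither moved the read-out beyond the scatter. The step of a number 3.7 percentage points higher from compound 2 to compound 4 (within the scatter) is therefore expected to stay within the scatter as well. Compound 4 is expected to give 15%, with a range from 4% to 28%.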

Compound 4, a percentage reported as inhibition, at one concentration (the size of the read-out at that concentration, not a potency): 16.3%
Compound 4: middle estimate off by 1.3 percentage points, on the low side; low and high end bracket the measured number.
By their numbers in this assay, from the lowest: compounds 1, 2, 4 and 3 (each within the scatter of the next).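

In this assay, putting 3,4,5-trimethoxyphenyl in place of phenyl gives a number 5 percentage points higher from compound 2 to compound 4 (within the scatter). The phenyl on this aromatic carbon, next to the ring oxygen, can thus be exchanged for a group with more heavy atoms and with hydrogen-bond acceptors, and the read-out still does not leave the scatter. No measurement offered here accounts for this result.

The compounds shown leave open whether an amine or a carboxylic acid on this phenyl would take the number beyond the scatter. They also leave open whether a pyridine ring in its place would do so.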